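The compounds below may be only part of what the source reports. "The series", "measured", "known", "first", "only" and "open" are said of these compounds alone.

Measured so far:
Compound 1 `O=S(=O)(NCCCNCc1ccccc1Cl)c1cc(C(F)(F)F)cc(C(F)(F)F)c1` gives 15000 nM in a functional assay on PANC-1 cells (Homo sapiens) for inhibition, read by MTT assay, with a stated time of 72 h; a lower number here means a stronger inhibitor of growth, a higher number a weaker inhibitor of growth.
Compound 2 `O=S(=O)(NCCCCNCc1ccc(Br)cc1)c1cc(C(F)(F)F)cc(C(F)(F)F)c1` gives 2200 nM.
Compound 3 `COc1ccc(CNCCCNS(=O)(=O)c2cc(C(F)(F)F)cc(C(F)(F)F)c2)cc1OC` gives 18000 nM.

Compound 3 has the highest number of the three, but its gap to compound 1 is within the scatter; only compound 2 lies beyond it. Compound 4 `O=S(=O)(NCCCNCc1cccc(Cl)c1)c1cc(C(F)(F)F)cc(C(F)(F)F)c1` differs from compound 3 by 3-chlorophenyl in place of 3,4-dimethoxyphenyl on a saturated chain carbon bound to an amine nitrogen. The closest comparison is a 1.2-fold higher number from compound 1 to compound 3 (0.08 log units; within the scatter), where a different chlorophenyl and the dimethoxyphenyl gave numbers within the scatter of each other. The step of a 6.8-fold lower number from compound 1 to compound 2 (0.83 log units; beyond the scatter) also changes the chain, so it bears only loosely. No step beyond the scatter is therefore expected here, a 1.5-fold lower number from compound 3 to compound 4 (0.18 log units; within the scatter). Compound 4 is estimated at 12000 nM, in the range 5000 nM to 30000 nM.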

Compound 4, concentration for 50% growth inhibition: 12000 nM
Estimate against measurement, compound 4: no gap at the digits printed; the range from low to high includes it.
By their numbers in this assay, from the lowest: compound 2; then compounds 4, 1 and 3 (each within the scatter of the next).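

In this assay, 3-chlorophenyl at this place reads like both earlier groups on the same chain: a 1.5-fold lower number from compound 3 to compound 4 (0.18 log units; within the scatter), and a 1.3-fold lower number from compound 1 to compound 4 (0.10 log units; within the scatter). Across these three compounds, neither the chlorine's position nor the swap from 3,4-dimethoxyphenyl separates the numbers. The step of a 5.5-fold higher number from compound 2 to compound 4 (0.74 log units; beyond the scatter) lies beyond the scatter, but it alters the chain and the ring group together, so it cannot be assigned to either. No supporting evidence bears on this result.

Still open, on these data alone, is whether compound 2 owes its lower number to its chain or to its 4-bromobenzyl group. Also open, as far as these compounds go, is how a nitrile on the ring would read.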